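Dichlorophenyl for Methoxy: Expected Cytotoxicity of Compound 3

This account rests on a few compounds, and the source may have more. Where it says the series, first, only, none or still open, it means among the compounds named here.

Compound 1 `C=C[C@@](C)(/C=C/c1ccc(OC)cc1)CCC=C(C)C` was tested in a functional assay on NALM-6 cells (Homo sapiens) for cytotoxicity, with a stated time of 72 h; a higher number here means that more compound is needed for the effect, a lower number that less compound is needed. In this assay compound 1 gives > 43400 nM, which is a limit of the assay and not a number. Compound 2 `C=C[C@@](C)(/C=C/c1ccc(O)cc1)CC/C=C(\C)CO` gives > 43400 nM in this assay, again only a limit. Compound 1 thus stands at the limit of > 43400 nM in this assay, at which 2 of the 2 values shown sit. Compound 3 `C=C[C@@](C)(/C=C/c1ccc(-c2ccc(Cl)c(Cl)c2)cc1)CCC=C(C)C` differs from compound 1 by 3,4-dichlorophenyl in place of methoxy on an aromatic carbon. Among the measured compounds shown here, no step between measured compounds is known, so the expected size is uncertain; a move toward lower values, beyond the scatter, is expected. For compound 3 the estimate is 15000 nM, between 3000 nM and 43400 nM. The step of an at least 2.8-fold lower number from compound 1 to compound 3 (0.46 log units; beyond the scatter) is expected accordingly.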

Compound 3, half-maximal effective concentration: > 43400 nM
Compound 3 was reported as a limit; the forecaster's own chance of this, stated with the estimate: 45%; middle value at least 2.8-fold (0.46 log units) away from the limit.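

In this assay compound 3 gives > 43400 nM, a limit of the assay and not a number. Among the compounds shown here, compound 1 also sits at a limit, so no step between compound 1 and compound 3 can be read. The compounds shown leave open at what concentration any of them would reach the effect in this assay: the limit of > 43400 nM in this assay, at which 3 of the 3 values shown sit.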